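Cycloheptyl for cyclohexyl on the shared core

A few compounds are considered here, and "the series" means these few. Any claim that something is new, unique, unknown or untested is made for them only; others in the source may bear on it.

In a functional assay on HT-29 cells (Homo sapiens) for inhibition, read by luminescence and CellTiter-Glo, with a stated time of 24 h (a higher number here means that more compound is needed for the effect, a lower number that less compound is needed), compound 1 (`CN1C(=S)[C@@H](NC(=O)c2nc(Cc3ccccc3)n(CCC(F)(F)F)n2)COc2ccccc21`) gives 1550 nM and compound 2 (`CN1C(=S)[C@@H](NC(=O)c2nc(Cc3ccccc3)n(CCCCC#N)n2)COc2ccccc21`) gives 2680 nM on the same core. Compound 3 (`CN1C(=S)[C@@H](NC(=O)c2nc(Cc3ccccc3)n(C3CCCCC3)n2)COc2ccccc21`) reads 4000 nM there, within the scatter of compound 2 and a modest step above compound 1. Compound 4 (`CN1C(=S)[C@@H](NC(=O)c2nc(Cc3ccccc3)n(C3CCCCCC3)n2)COc2ccccc21`) carries cycloheptyl in place of cyclohexyl on an aromatic nitrogen. Among the measured compounds shown here, no measured step changes ring size. The nearest evidence is the two swaps of open chains for cyclohexyl (a 1.5-fold higher number from compound 2 to compound 3 (0.17 log units; within the scatter) and a 2.6-fold higher number from compound 1 to compound 3 (0.41 log units; beyond the scatter)), which are at most modest, so this assay is expected to show no step beyond the scatter here. The expected move (a 1.1-fold lower number from compound 3 to compound 4 (0.02 log units; within the scatter)) is therefore slight. Compound 4 is estimated at 3800 nM with a likely range from 1800 nM to 8000 nM in this measurement.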

Compound 4, half-maximal effective concentration: 5530 nM
For compound 4 the middle estimate is 1.5-fold (0.16 log units) below the measured one; measured number inside the range.
By their numbers in this assay, from the lowest: compounds 1, 2, 3 and 4 (each within the scatter of the next, the first and the last beyond it).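

In this assay, the change of ring size on this aromatic nitrogen does not separate the two compounds, with a 1.4-fold higher number from compound 3 to compound 4 (0.14 log units; within the scatter). Cycloheptyl does stand modestly apart from both open chains, with a 2.1-fold higher number from compound 2 to compound 4 (0.31 log units; beyond the scatter) and a 3.6-fold higher number from compound 1 to compound 4 (0.55 log units; beyond the scatter), whereas cyclohexyl stands apart only from 3,3,3-trifluoropropyl and remains within the scatter of 4-cyanobutyl. Nothing available here accounts for these differences. The compounds shown leave open how a smaller cyclopentyl ring would read at this position. They also leave open whether an amine or a carboxylic acid on the cycloheptyl ring would shift the number.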